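The source may hold more compounds than are shown below. What is called first, only, known or untested is meant among the compounds shown, and "the series" means these compounds.

Three compounds share one core and differ only in the aryl group on the amide nitrogen. Compound 1 `Cc1ccc(NC(=O)COc2ccc3cc(/C=C4/SC(=O)NC4=O)ccc3c2)cc1` gives 1700 nM in an assay on isolated protein for inhibition of histone deacetylase 4 (Homo sapiens), with a stated time of 1 h; a lower number here means a stronger inhibitor, a higher number a weaker inhibitor. Compound 2 `COc1cccc(NC(=O)COc2ccc3cc(/C=C4/SC(=O)NC4=O)ccc3c2)c1` gives 1600 nM in this assay, and compound 3 `O=C(COc1ccc2cc(/C=C3/SC(=O)NC3=O)ccc2c1)Nc1ccc([N+](=O)[O-])cc1` gives 1700 nM. Compound 2 shows the lowest of the three numbers, yet its nearest and furthest neighbours sit at the same distance, with a 1.1-fold lower number from compound 1 to compound 2 (0.03 log units; within the scatter) and a 1.1-fold higher number from compound 2 to compound 3 (0.03 log units; within the scatter), so the three are not separated. The unmeasured compound 4 `O=C(COc1ccc2cc(/C=C3/SC(=O)NC3=O)ccc2c1)Nc1cc(Cl)cc(C(F)(F)F)c1` carries 3-chloro-5-(trifluoromethyl)phenyl in place of 3-methoxyphenyl on an amide-type nitrogen. Among the measured compounds shown here, the steps that bear on this change all exchange one aryl substituent for another on the same nitrogen: no change at the digits printed from compound 1 to compound 3 (within the scatter) joins the two already named, and none of them shifted the number beyond the scatter. The step of no change at the digits printed from compound 2 to compound 4 (within the scatter) is therefore expected to stay within the scatter as well. Compound 4 is estimated at 1600 nM, with a range from 700 nM to 3600 nM.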

Compound 4, half-maximal inhibitory concentration: 4000 nM
The estimate for compound 4 lay 2.5-fold (0.40 log units) below the measured number, outside the stated range (above it).
By their numbers in this assay, from the lowest: compounds 2, 1 and 3 (each within the scatter of the next); then compound 4.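

In this assay the aryl group on the amide-type nitrogen can move the number beyond the scatter, which the earlier exchanges at this place did not show: 3-chloro-5-(trifluoromethyl)phenyl gives a 2.5-fold higher number from compound 2 to compound 4 (0.40 log units; beyond the scatter) and a 2.4-fold higher number from compound 1 to compound 4 (0.37 log units; beyond the scatter) and a 2.4-fold higher number from compound 3 to compound 4 (0.37 log units; beyond the scatter), all modest steps towards a weaker inhibitor. The flat picture from compounds 1, 2 and 3 therefore holds only for those three aryl groups, and compound 4 goes against it. No measurement at hand explains this shift. The compounds shown leave open whether the chloro or the trifluoromethyl group alone would give the same step, since compound 4 carries both. They also leave open how an amine or a carboxylic acid on the phenyl ring would compare at this place.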